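This account rests on a few compounds, and the source may have more. Where it says the series, first, only, none or still open, it means among the compounds named here.

Within the data shown here, in a functional assay on MCF7 cells (Homo sapiens) for antiproliferative activity, read by MTT assay, with a stated time of 48 h (a lower number here means a stronger inhibitor, a higher number a weaker inhibitor), compound 1 `COc1ccc(C(=O)c2ccc(OC)c3c2C=CC(C)(C)O3)c(NC(=O)CN)c1` gives 1250 nM, the lowest of the two numbers measured so far. Compound 2 `CCNCC(=O)Nc1cc(OC)ccc1C(=O)c1ccc(OC)c2c1OC(C)(C)C=C2` gives 5200 nM, a gap beyond the usual scatter. Compound 3 `COc1ccc(C(=O)c2ccc(OC)c3c2C=CC(C)(C)O3)c(NC(=O)CN(C)C)c1` has not yet been measured. It differs from compound 1 in one place, with dimethylamino in place of amino on a saturated chain carbon bound to a carbonyl carbon. Among the measured compounds shown here, no two measured compounds differ in just one place, so the data show no direct precedent for this change. For the measured compounds named here, the only guide is thin: compound 2, at 5200 nM, is a weaker inhibitor than compound 1. On that basis, a moderate step toward a weaker inhibitor is expected in this assay, though a step within the scatter remains possible. The estimated step is a 2.1-fold higher number from compound 1 to compound 3 (0.32 log units; beyond the scatter). For compound 3, the estimated value is 2600 nM, with an expected range of 900 nM to 7500 nM.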

Compound 3, half-maximal inhibitory concentration: 6530 nM
Beside the measured number, compound 3's estimate is 2.5-fold (0.40 log units) below it; the range from low to high includes it.
By their numbers in this assay, from the lowest: compound 1; then compounds 2 and 3 (each within the scatter of the next).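

In this assay, among these compounds, the swap to dimethylamino in place of amino, on a saturated chain carbon bound to a carbonyl carbon, gives a 5.2-fold higher number from compound 1 to compound 3 (0.72 log units; beyond the scatter) and provides the first direct reading of a change at this position. Since the two compounds differ in this one place, the weaker result goes with this swap on this core, and of these two groups the plain amino gives the stronger inhibitor. Nothing measured here shows why the number rises.

Going by these compounds, with only these two groups compared directly, it remains open whether a group of intermediate size, such as methylamino, would fall between them. On these data alone, it also remains open whether a pyrrolidine ring at this carbon, or a longer chain carrying the amino group, would keep the strength of compound 1.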